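A few compounds are considered here, and "the series" means these few. Any claim that something is new, unique, unknown or untested is made for them only; others in the source may bear on it.

Working notes on a small series tested for cytotoxicity. Compound 1 `COc1ccc(-n2nc(-c3ccc(F)cc3)cc2-c2ccc3cc(F)ccc3n2)cc1` serves as the reference. In an ADME assay on Huh-7 cells (Homo sapiens) for cytotoxicity, read by XTT assay, with a stated time of 3 days, tested at 20 uM (a lower number here means a stronger effect, a higher number a weaker effect of the compound at the concentration tested), compound 1 gives 89.1%. Compound 2 `COc1ccc(-c2cc(-c3ccc4cc(F)ccc4n3)n(-c3ccc(OC)cc3)n2)cc1` differs from it by methoxy in place of fluoro on an aromatic carbon; in this assay compound 2 gives 95.8%, so the step of a number 6.7 percentage points higher from compound 1 to compound 2 (within the scatter) is read as no real change. Compound 3 `NS(=O)(=O)c1ccc(-n2nc(-c3ccc(F)cc3)cc2-c2ccc3cc(F)ccc3n2)cc1` differs from compound 1 by sulfamoyl in place of methoxy on an aromatic carbon, and in this assay compound 3 gives 91.1%; the step of a number 2 percentage points higher from compound 1 to compound 3 (within the scatter) is likewise flat. All three measured compounds thus sit at high remaining cell viability, none clearly apart from the others.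

Compound 4 `COc1ccc(-c2cc(-c3ccc4cc(F)ccc4n3)n(-c3ccc(S(N)(=O)=O)cc3)n2)cc1` has not yet been measured. It stands to compound 3 as compound 2 stands to compound 1: the difference is methoxy in place of fluoro on an aromatic carbon, the same change at the same place as before, while the cores of the two pairs differ by the counted difference given for compound 3 against compound 1. Among the measured compounds shown here, the only precedent for this change, the step from compound 1 to compound 2, stayed within the scatter, and compound 3 already sits near the top of the measured range, so the expected step of a number 2.9 percentage points higher from compound 3 to compound 4 (within the scatter) in this assay is small and rests on that single earlier step. Compound 4 is therefore estimated at 94% in this assay, with a plausible range from 84% to 102%.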

Compound 4, a percentage reported as activity, at one concentration (the size of the read-out at that concentration, not a potency): 83.7%
Compound 4: middle estimate off by 10.3 percentage points, on the high side; the measured number lies below the stated range.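

The step of a number 7.4 percentage points lower from compound 3 to compound 4 (within the scatter) is no real change when taken alone, but set beside the earlier step it shows that going from 4-fluorophenyl to 4-methoxyphenyl does not carry over as a fixed increment from one core to the other in this assay: the same change on two cores in this assay, a number 6.7 percentage points higher (within the scatter) from compound 1 to compound 2 and a number 7.4 percentage points lower (within the scatter) from compound 3 to compound 4, 14.1 percentage points apart, beyond the scatter of two such steps. Among the compounds shown here, the step of a number 12.1 percentage points lower from compound 2 to compound 4 (beyond the scatter) is the only single step in this set beyond the scatter, and sulfamoyl in place of methoxy likewise gives a different result on the two cores: the same change on two cores in this assay, a number 2 percentage points higher (within the scatter) from compound 1 to compound 3 and a number 12.1 percentage points lower (beyond the scatter) from compound 2 to compound 4, 14.1 percentage points apart, beyond the scatter of two such steps. Both comparisons rest on the same four compounds and so form a single observation of non-additivity rather than two independent ones, and they show neither why the steps differ nor whether the same would hold outside this set.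

Open, as far as these compounds go, is whether the modest drop seen with compound 4 depends on these two particular groups occurring together, or would recur if the methoxy were replaced by an amine or the sulfamoyl by a carboxylic acid. Also open, from the compounds shown here alone, is whether the gap between the two steps would persist on repeat measurement, since all four compounds lie close to the top of the range and the steps are small.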